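A few compounds are considered here, and "the series" means these few. Any claim that something is new, unique, unknown or untested is made for them only; others in the source may bear on it.

Series in a functional assay on HaCaT cells (Homo sapiens) for antiproliferative activity, read by sulforhodamine B assay, with a stated time of 3 days; on this read-out higher numbers stand for weaker inhibition and lower numbers for stronger inhibition
compound 1 `COC(=O)c1cc(CCc2cc(OC)ccc2Br)ccc1O` gives 210 nM
compound 2 `COC(=O)c1cc(CCc2cc(OC)ccc2N(C)C)ccc1O` gives 650 nM
compound 3 `CCc1ccc(OC)cc1CCc1ccc(O)c(C(=O)OC)c1` gives 130 nM

Compound 3 lies clearly under compound 2 (a 5.0-fold lower number from compound 2 to compound 3 (0.70 log units; beyond the scatter)) but is not separated from compound 1 (a 1.6-fold lower number from compound 1 to compound 3 (0.21 log units; within the scatter)). Compound 4 `CCc1ccc(CC)c(CCc2ccc(O)c(C(=O)OC)c2)c1` differs from compound 3 at the methoxy, with ethyl in place of methoxy on an aromatic carbon. Among the compounds with values here, no measured step changes the methoxy, so the evidence is only indirect. The measured steps exchange bromo, dimethylamino and ethyl elsewhere, and only those involving compound 2 pass the scatter, the other being (a 3.1-fold higher number from compound 1 to compound 2 (0.49 log units; beyond the scatter)). No step beyond the scatter is expected in this assay, and the estimated change is small (a 1.4-fold higher number from compound 3 to compound 4 (0.14 log units; within the scatter)). Compound 4 is estimated at 180 nM (range 60 nM to 550 nM).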

Compound 4, half-maximal inhibitory concentration: 650 nM
Compound 4: the middle estimate sits 3.6-fold (0.56 log units) below what was measured; measured number outside the range, above it.
By their numbers in this assay, from the lowest: compounds 3 and 1 (each within the scatter of the next); then compounds 2 and 4 (each within the scatter of the next).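

Within the data shown here, the methoxy position is not indifferent in this assay: ethyl in place of methoxy, on the carbon para to an ethyl group, gives a 5.0-fold higher number from compound 3 to compound 4 (0.70 log units; beyond the scatter) and is the first measured change at this place. Ethyl is not interchangeable between the two substituted places, since ethyl in place of bromo at the other place gives only a 1.6-fold lower number from compound 1 to compound 3 (0.21 log units; within the scatter) and stays within the scatter. Nothing measured here accounts for the step.

As far as these compounds go, whether the loss follows removal of the oxygen or the ethyl itself remains open. Hydroxy, fluoro or ethoxy at this place would bear on that.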